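This account rests on a few compounds, and the source may have more. Where it says the series, first, only, none or still open, it means among the compounds named here.

Compound 1 `CCCCCCCCNC[C@@H]1OC[C@H](N)[C@@H]1O` is the starting point here, and its activity is known only as a limit. In a functional assay on B16-F10 cells (Mus musculus) for antiproliferative activity, read by MTT assay, with a stated time of 72 h (on this read-out lower numbers stand for stronger inhibition and higher numbers for weaker inhibition), compound 1 gives > 128000 nM, which is a limit and not a number. Compound 2 `CCCCCCCCNC[C@@H]1OC[C@H](N)[C@H]1O` has the same atoms and bonds. In this assay, compound 2 gives > 128000 nM, which is also a limit. Going by the values given here, the only measured step is a step that the two limits leave unreadable from compound 1 to compound 2. Among the compounds with values here, the sole contrast behind that step is the fact that compounds 1 and 2 differ only in the configuration as drawn, so it offers no size to carry over to a change in the chain.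

Compound 3 `CCCCCCCCCNC[C@@H]1OC[C@H](N)[C@@H]1O` keeps the core of compound 1 and alters only the chain: methyl in place of hydrogen on a saturated chain carbon, eight bonds along the chain from an amine nitrogen. The new methyl replaces a hydrogen on a saturated chain carbon, eight bonds along the chain from an amine nitrogen. Within the data shown here, the only reference point is the limit of > 128000 nM in this assay, at which 2 of the 2 values shown sit, so no measured step gives a direction, and no change beyond the usual scatter is expected. The expected step is a step that the limit leaves unreadable from compound 1 to compound 3. For compound 3, the estimated value is 130000 nM, with an expected range from 64000 nM to 260000 nM.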

Compound 3, half-maximal inhibitory concentration: 55200 nM
Compound 3: the middle estimate sits 2.4-fold (0.37 log units) above what was measured; the measured number lies below the stated range.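

Adding one methyl on a saturated chain carbon, eight bonds along the chain from an amine nitrogen, is the first change here that visibly moves the read-out in this assay, giving an at least 2.3-fold lower number from compound 1 to compound 3 (0.36 log units; beyond the scatter). Going by these compounds alone, compound 3 is also the first compound here with a real number and not a limit, which shows that one added carbon at this place on the chain can shift the result towards stronger inhibition. The size of the step is only a minimum, and its starting point is a limit and not a number: the limit of > 128000 nM in this assay, at which 2 of the 3 values shown sit.

As far as these compounds go, it remains open whether a longer chain would lower the number further, or whether a hydroxyl or a carboxylic acid on the chain would keep or lose this gain. Also open, from the compounds shown here alone, is whether the change in configuration that separates compound 1 from compound 2, which could not be read at the limit, would make a readable difference on the chain of compound 3.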